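Swapping One Halogenated Aryl Ring for Another

A few compounds are considered here, and "the series" means these few. Any claim that something is new, unique, unknown or untested is made for them only; others in the source may bear on it.

Measured so far:
compound 1 `O=C1CSC(c2c(Cl)cccc2Cl)N1CCN1CCCCC1`: 100%
compound 2 `O=C1CSC(c2cccc(Cl)c2)N1CCN1CCCCC1`: 100%
compound 3 `Cc1ccc(C2SCC(=O)N2CCN2CCCCC2)cc1`: 100%

All three compounds share one core and differ only in the aryl group hanging from a saturated ring carbon. In an ADME assay on Vero cells (Chlorocebus sabaeus) for cytotoxicity, read by neutral red uptake, tested at 25 ug/mL (on this read-out lower numbers stand for a stronger effect and higher numbers for a weaker effect at the one concentration tested), compound 1 gives 100%, compound 2 gives 100% and compound 3 gives 100%. Compound 2 therefore stands level with both neighbours at the digits shown, with nothing separating it from compound 1 or compound 3 beyond the scatter. For the measured compounds named here, the only single-point step recorded, no change at the digits printed from compound 2 to compound 3 (within the scatter), shows that replacing the aryl group left the read-out unchanged.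

Compound 4 `O=C1CSC(c2ccc(F)cc2)N1CCN1CCCCC1` has not yet been measured. Its difference from compound 2 is 4-fluorophenyl in place of 3-chlorophenyl on a saturated ring carbon. This is the same kind of change as the step from compound 2 to compound 3, an exchange of one aryl group for another at the same place, and that step produced no shift. Going by the values given here, because no change at the digits printed from compound 2 to compound 3 (within the scatter) showed nothing beyond the scatter, the expectation for compound 4 is likewise no step, no change at the digits printed from compound 2 to compound 4 (within the scatter). Compound 4 is thus estimated at 100%, within a range from 88% to 100%.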

Compound 4, a percentage reported as activity, at one concentration (the size of the read-out at that concentration, not a potency): 100%
For compound 4 middle estimate and measured number coincide at the digits printed, and the stated range covers the measured number.
By their numbers in this assay, from the lowest: compounds 1, 2, 3 and 4 (each within the scatter of the next).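

With fluorine, a different halogen from the chlorine of compound 2, the picture at this saturated ring carbon stays the same: in this assay the exchange of 3-chlorophenyl for 4-fluorophenyl gives no change at the digits printed from compound 2 to compound 4 (within the scatter). The change of fluoro for methyl on an aromatic carbon adds a direct comparison between two para-free named rings, 4-methylphenyl and 4-fluorophenyl, and gives no change at the digits printed from compound 3 to compound 4 (within the scatter). Nothing available explains why the read-out stays flat.

All four compounds carry a phenyl ring with only chloro, methyl or fluoro on it, so these results do not show whether any group at this position can move the read-out. A phenyl ring bearing an amine or a carboxylic acid, or a longer alkyl chain in place of the ring, remains an open case.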